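A Second Hydroxy for Compound 3

The source may report more compounds than this note shows. Statements on the series, on what has been measured and on what is new or still open speak of the compounds shown alone.

- compound 1 `COc1ccc(-c2nnnn2-c2cc(OC)c(OC)c(OC)c2)c(O)c1O` gives 6700 nM
- compound 2 `COc1ccc(-c2nnnn2-c2cc(OC)c(OC)c(OC)c2O)cc1` gives > 100000 nM
- compound 3 `COc1ccc(-c2nnnn2-c2cc(OC)c(OC)c(OC)c2)c(O)c1` gives 6400 nM

In a functional assay on A549 cells (Homo sapiens) for inhibition, read by MTT assay, with a stated time of 48 h (on this read-out higher numbers stand for weaker inhibition and lower numbers for stronger inhibition), only compound 1 and compound 3 have true numbers, and these lie within the scatter of each other. Compound 2 gives > 100000 nM, which is a limit of the assay and not a number. Compound 4 `COc1ccc(-c2nnnn2-c2cc(OC)c(OC)c(OC)c2O)c(O)c1` differs from compound 3 by hydroxy in place of hydrogen on an aromatic carbon. For the measured compounds named here, the one measured step, a 1.0-fold lower number from compound 1 to compound 3 (0.02 log units; within the scatter), involves a hydroxy at a different place and stays within the scatter, so it gives little guidance. Compound 2 does carry a hydroxy at the new place, and its limit of > 100000 nM suggests weaker inhibition. The expected change is a 3.9-fold higher number from compound 3 to compound 4 (0.59 log units; beyond the scatter). For compound 4 the estimate is 25000 nM, with an expected range of 7000 nM to 90000 nM.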

Compound 4, half-maximal inhibitory concentration: 50000 nM
Estimate against measurement, compound 4: 2.0-fold (0.30 log units) below; measured number inside the range.
By their numbers in this assay, from the lowest: compounds 3 and 1 (each within the scatter of the next); then compound 4. At a limit, above all of these: compound 2.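

In this assay, this place, ortho to a large group and para to a methoxy group, now has a true measured change: hydroxy in place of hydrogen gives a 7.8-fold higher number from compound 3 to compound 4 (0.89 log units; beyond the scatter). Until now only a limit spoke for this place. Compound 2 gives > 100000 nM, which is a limit of the assay and not a number. Against that limit the data give an at least 2.0-fold lower number from compound 2 to compound 4 (0.30 log units; that floor lies within the scatter).

Going by these compounds, whether an amine or a carboxylic acid at this place would behave like hydroxy stays open. Also open is whether the hydroxy on the other ring counts for the same on each core: the same change on two cores in this assay, a 1.0-fold lower number (0.02 log units; within the scatter) from compound 1 to compound 3 and an at least 2.0-fold higher number (0.30 log units; that floor lies within the scatter) from compound 4 to compound 2; the limit leaves it open whether they differ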